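The compounds below may be only part of what the source reports. "The series", "measured", "known", "first", "only" and "open" are said of these compounds alone.

Measured in a functional assay on MDA-MB-231 cells (Homo sapiens) for antiproliferative activity, read by MTT assay, with a stated time of 24 h; a higher number here means a weaker inhibitor, a lower number a stronger inhibitor:
- compound 1 `O=C(c1cc(Cl)ccn1)N1CCN(c2nccc(Oc3cc(Cl)cc(Cl)c3)n2)CC1`: 16700 nM
- compound 2 `O=S(=O)(c1ccccc1)N1CCN(c2nccc(Oc3cc(Cl)cc(Cl)c3)n2)CC1`: > 50000 nM
- compound 3 `O=S(=O)(c1cccnc1)N1CCN(c2nccc(Oc3cc(Cl)cc(Cl)c3)n2)CC1`: 24800 nM

Among the compounds with values here, compound 3 has one of only two true numbers, and the other belongs to compound 1. The two cannot be told apart: a 1.5-fold higher number from compound 1 to compound 3 (0.17 log units; within the scatter). For compound 2, > 50000 nM is a limit of this assay and not a number.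

Compound 4 `O=S(=O)(c1ccc(F)cc1)N1CCN(c2nccc(Oc3cc(Cl)cc(Cl)c3)n2)CC1` keeps the core and sulfonyl link of compound 3 and changes one group: 4-fluorophenyl in place of pyridin-3-yl on a sulfonyl sulfur. This puts 4-fluorophenyl in place of pyridin-3-yl on a sulfonyl sulfur.

The closest measured comparison is the step between the phenyl and pyridin-3-yl sulfonyl compounds: an at least 2.0-fold lower number from compound 2 to compound 3 (0.30 log units; that floor lies within the scatter). Within the data shown here, compound 4 goes back to a ring of carbon only, so it should resemble compound 2 more than compound 3, although no measured compound carries the fluorine. The other step involving compound 2 points the same way: an at least 2.9-fold higher number from compound 1 to compound 2 (0.47 log units; beyond the scatter). A move towards a higher number, meaning weaker inhibition, is therefore expected, and the assay may report only a limit.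

The expected change is a 1.7-fold higher number from compound 3 to compound 4 (0.23 log units; within the scatter). Compound 4 is estimated at 42000 nM, with an expected range of 20000 nM to 85000 nM.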

Compound 4, half-maximal inhibitory concentration: > 50000 nM
Compound 4: no number, only a limit (the forecaster's own chance of this, stated with the estimate: 50%); middle value at least 1.1-fold (0.07 log units) away from the limit.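

In this assay, compound 4 gives > 50000 nM, which is a limit and not a number. Replacing pyridin-3-yl with 4-fluorophenyl on the sulfonyl sulfur gives an at least 2.0-fold higher number from compound 3 to compound 4 (0.30 log units; that floor lies within the scatter), so the true size of this change remains unknown, and among the sulfonyl compounds shown, only the one with the pyridin-3-yl ring gives a true number. Replacing the (4-chloropyridin-2-yl)carbonyl group with (4-fluorophenyl)sulfonyl on the ring nitrogen gives an at least 2.9-fold higher number from compound 1 to compound 4 (0.47 log units; beyond the scatter), which is a change beyond the scatter and adds a second sulfonyl compound with a carbon-only ring that reaches the limit.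

As far as these compounds go, the effect of fluoro in place of hydrogen cannot be read, because the step from compound 2 to compound 4 compares two values that are both limits: the limit of > 50000 nM in this assay, at which 2 of the 4 values shown sit. It also remains open whether an amine or a carboxylic acid on the ring attached to the sulfonyl sulfur would give a true number in this assay, and how such a compound would compare with compound 3.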